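The source may report more compounds than this note shows. Statements on the series, on what has been measured and on what is new or still open speak of the compounds shown alone.

Going by the values given here, compound 1 `COc1cccc(/C=C2\CCC/C(=C\c3cccc(Cl)c3)C2=O)c1OC` is examined in an ADME assay on NHDF cells (Homo sapiens) for cytotoxicity, read by MTT assay, with a stated time of 72 h (on this read-out lower numbers stand for stronger inhibition and higher numbers for weaker inhibition), where compound 1 gives 21400 nM and stands second highest of the three numbers known. Compound 2 `COc1cccc(/C=C2\CCC/C(=C\c3cccc(Br)c3)C2=O)c1OC` gives 23900 nM, and compound 3 `COc1cccc(/C=C2\CCC/C(=C\c3cccc(OC)c3OC)C2=O)c1` gives 16400 nM. The change to compound 4 `COc1cccc(/C=C2\CCC/C(=C\c3ccc(O)c(O)c3)C2=O)c1OC` is 3,4-dihydroxyphenyl in place of 3-chlorophenyl on a double-bonded chain carbon bound to a double-bonded ring carbon. Among the compounds with values here, two measured steps bear on it: a 1.1-fold higher number from compound 1 to compound 2 (0.05 log units; within the scatter), and a 1.3-fold lower number from compound 1 to compound 3 (0.12 log units; within the scatter); the step of a 1.5-fold lower number from compound 2 to compound 3 (0.16 log units; within the scatter) is of the same order. All three lie within the scatter, so exchanging the group on that chain carbon has so far left this read-out unchanged. Compound 4 is therefore expected to show no step beyond the scatter, a 1.2-fold lower number from compound 1 to compound 4 (0.08 log units; within the scatter), with an estimate of 18000 nM and a range from 8000 nM to 40000 nM.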

Compound 4, half-maximal inhibitory concentration: 17900 nM
Beside the measured number, compound 4's estimate is 1.0-fold (0.00 log units) above it; the measured number falls inside the stated range.
By their numbers in this assay, from the lowest: compounds 3, 4, 1 and 2 (each within the scatter of the next).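

In this assay, 3,4-dihydroxyphenyl on the double-bonded chain carbon gives a 1.2-fold lower number from compound 1 to compound 4 (0.08 log units; within the scatter) and a 1.1-fold higher number from compound 3 to compound 4 (0.04 log units; within the scatter) and a 1.3-fold lower number from compound 2 to compound 4 (0.13 log units; within the scatter). Unlike 3-chlorophenyl, the entering group carries hydrogen-bond donors and acceptors, yet this exchange also stays within the scatter, so the earlier finding now extends to a group of that kind. No measurement shown accounts for this result. The compounds shown leave open whether an amine, a carboxylic acid or a longer chain on that carbon would move the number in this assay beyond the scatter.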